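Isopentyl for 2-methylprop-1-en-1-yl: working notes

The compounds below may be only part of what the source reports. "The series", "measured", "known", "first", "only" and "open" are said of these compounds alone.

Limits in an ADME assay on Huh-7 cells (Homo sapiens) for cytotoxicity, with a stated time of 72 h; on this read-out lower numbers stand for higher toxicity in this test and higher numbers for lower toxicity in this test:
Compound 1 `CC(C)CCn1nc(CC2=CCCC2)c(O)c(C2=NS(=O)(=O)c3cc(NS(C)(=O)=O)ccc3N2)c1=O`: > 33000 nM
Compound 2 `CC(C)=Cc1nn(CCC(C)C)c(=O)c(C2=NS(=O)(=O)c3cc(NS(C)(=O)=O)ccc3N2)c1O`: > 1000 nM
Compound 3 `CC(C)CCc1nn(CCC(C)C)c(=O)c(C2=NS(=O)(=O)c3cc(NS(C)(=O)=O)ccc3N2)c1O`: not yet measured

Compound 2 stands only at its limit of > 1000 nM, with no number behind it. The change to compound 3 is isopentyl in place of 2-methylprop-1-en-1-yl on an aromatic carbon, on an aromatic carbon next to the ring nitrogen. Among the compounds with values here, the one measured step at this place, a step that the two limits leave unreadable from compound 1 to compound 2, offers no size to carry over. In this assay no firm direction can be argued, and another limit is the likeliest report. The expected step that the limit leaves unreadable from compound 2 to compound 3 is reckoned from a limit and is only a loose estimate. For compound 3 the estimate is 10000 nM, with an expected range of 2000 nM to 50000 nM.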

Compound 3, half-maximal cytotoxic concentration: > 33000 nM
Compound 3: no number, only a limit; the forecaster's own chance of this, stated with the estimate: 80%; middle value at least 3.3-fold (0.51 log units) away from the limit.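

Within the data shown here, compound 3 gives only a limit, > 33000 nM, so no step among compound 1, compound 2 and compound 3 can be read in this assay. The compounds shown leave open whether these group changes alter the half-maximal cytotoxic concentration at all.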